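The source may report more compounds than this note shows. Statements on the series, on what has been measured and on what is new or still open speak of the compounds shown alone.

Compound 1 `O=C(O)CCc1ccc(OCc2cccc(Br)c2)cc1` is the most potent of the three measured compounds in a functional assay on 1321-N1 cells for agonist activity at Free fatty acid receptor 1 (Homo sapiens), read by calcium flux (on this read-out higher numbers stand for an effect only at larger amounts of compound and lower numbers for an effect already at smaller amounts), where compound 1 gives 89.1 nM. Compound 2 `O=C(O)CCc1ccc(NCc2ccc(Oc3ccccc3)cc2)cc1` gives 182 nM in this assay, a gap beyond the usual scatter, and compound 3 `O=C(O)CCc1ccc(NCc2ccccc2-c2ccccc2)cc1` gives 1070 nM, further still. Compound 4 `COc1ccccc1-c1cccc(COc2ccc(CCC(=O)O)cc2)c1` is built from compound 1 by a single change, (2-methoxyphenyl in place of bromo on an aromatic carbon), so that a larger aromatic piece now sits where the halogen did. Going by the values given here, because compound 1 already stands at 89.1 nM, and no directly comparable step among the measured compounds exists, the expected change is a moderate drop in the number, meaning activity at smaller amounts; the estimated step is a 2.5-fold lower number from compound 1 to compound 4 (0.41 log units; beyond the scatter). Compound 4 is expected to give about 35 nM in this assay, within a range from 10 nM to 120 nM.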

Compound 4, half-maximal effective concentration: 120 nM
Beside the measured number, compound 4's estimate is 3.4-fold (0.54 log units) below it, within the range that was stated.
By their numbers in this assay, from the lowest: compounds 1, 4 and 2 (each within the scatter of the next, the first and the last beyond it); then compound 3.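

Putting 2-methoxyphenyl in place of bromo on this aromatic carbon gives a 1.3-fold higher number from compound 1 to compound 4 (0.13 log units; within the scatter) in this assay. This position therefore holds a group of 8 heavy atoms with its own ring, where compound 1 carries a single bromine, and the number stays within the scatter. Nothing at hand gives a reason for this result.

From the compounds shown here alone, whether the methoxy group on the added ring matters remains open. So does how a plain phenyl ring, or a more basic group such as an aminomethyl, would read on this same carbon.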